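The compounds below may be only part of what the source reports. "The series", "measured", "known", "first", "only" and "open" are said of these compounds alone.

Measured so far:
compound 1 `CC(=O)c1ccc(NC(=O)Nc2cc(C)nc3ccccc23)cc1`: 19000 nM
compound 2 `Cc1cc(NC(=O)Nc2cc(F)ccc2F)c2ccccc2n1`: > 25000 nM (a limit)

For the measured compounds named here, in an ADME assay on HepG2 cells (Homo sapiens) for cytotoxicity, with a stated time of 72 h (a lower number here means that less compound is needed, a higher number that more compound is needed for the effect), compound 1 gives 19000 nM, the only plain number so far. Compound 2 returns only a limit of this assay, > 25000 nM, and not a number; the series thus has one value sitting at the limit of > 25000 nM in this assay, at which 1 of the 2 values shown sits. Compound 3 `COc1ccc(NC(=O)Nc2cc(C)nc3ccccc23)cc1` differs from compound 1 by methoxy in place of acetyl on an aromatic carbon. Going by the values given here, no step between two measured compounds is available, so the size of this change rests on no precedent. Because compound 1 itself lies at 19000 nM, a weak reading, a further move toward a higher number is more plausible than a move toward a lower one, but the expected step is small, at most at the edge of the scatter. Compound 3 is expected to give 24000 nM, with a range from 10000 nM to 60000 nM. The expected step is a 1.3-fold higher number from compound 1 to compound 3 (0.10 log units; within the scatter), essentially none beyond the scatter, with a real chance that only a limit is reported.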

Compound 3, half-maximal effective concentration: > 25000 nM
Compound 3 gave a limit, no number; the forecaster's own chance of this, stated with the estimate: 45%; middle value at least 1.0-fold (0.01 log units) away from the limit.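

In this assay, methoxy in place of acetyl on an aromatic carbon, para to a large group, gives an at least 1.3-fold higher number from compound 1 to compound 3 (0.11 log units; that floor lies within the scatter). For the compounds shown here, this is the first step read at this position, and it shows no move toward a lower number, though its floor does not establish a real change and its true size stays unknown. With this result, most of the series shown sits at the end of the read-out: the limit of > 25000 nM in this assay, at which 2 of the 3 values shown sit.

Going by these compounds alone, compound 1 remains the only plain number, so a step from acetyl to a group that gives a lower number has yet to be seen. On these data alone, whether an amine or a carboxylic acid at this position would give a plain number in this assay, and on which side of compound 1 it would fall, stays open.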